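The compounds below may be only part of what the source reports. "The series", "measured", "known", "first", "only" and "open" are said of these compounds alone.

In an assay on isolated protein for displacement of a labelled ligand from Gonadotropin-releasing hormone receptor (Rattus norvegicus) (a higher number here means a weaker inhibitor, a lower number a stronger inhibitor), compound 1 `CCc1cc(CN2CCN(c3cccc4[nH]c(-c5ccc(C(C)(C)C)cc5)nc34)CC2)n(C)n1` gives 250 nM, compound 2 `CCc1cc(CN2CCN(c3cccc4[nH]c(-c5ccc(C(C)(C)C)cc5)nc34)CC2)nn1C` gives 350 nM, and compound 3 `CCc1nc(CN2CCN(c3cccc4[nH]c(-c5ccc(C(C)(C)C)cc5)nc34)CC2)cn1C` gives 78 nM. Compound 3 therefore has the lowest number of the three: the step of a 3.2-fold lower number from compound 1 to compound 3 (0.51 log units; beyond the scatter) and the step of a 4.5-fold lower number from compound 2 to compound 3 (0.65 log units; beyond the scatter) both lie beyond the scatter, while the step of a 1.4-fold higher number from compound 1 to compound 2 (0.15 log units; within the scatter) does not.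

Compound 4 `CCCCc1nc(CN2CCN(c3cccc4[nH]c(-c5ccc(C(C)(C)C)cc5)nc34)CC2)cn1C` differs from compound 3 by one change: ethyl in place of hydrogen on a saturated chain carbon, two bonds along the chain from an aromatic carbon. Among the measured compounds shown here, none of the measured steps touches this spot. For the measured compounds named here, each of them swaps the whole aromatic ring that sits on the saturated chain carbon, and none lengthens the chain on that ring, so there is no measured step of the same kind to lean on. The three values do show that changes around this ring shift the number by modest amounts at most.

The expected outcome is a step of a 1.1-fold higher number from compound 3 to compound 4 (0.04 log units; within the scatter) in this assay, with no confident direction. Compound 4 is estimated at 85 nM, within a range from 30 nM to 250 nM.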

Compound 4, half-maximal inhibitory concentration: 58 nM
Compound 4: middle estimate off by 1.5-fold (0.17 log units), on the high side; measured number inside the range.
By their numbers in this assay, from the lowest: compounds 4 and 3 (each within the scatter of the next); then compounds 1 and 2 (each within the scatter of the next).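

In this assay, among the compounds shown here, the step of a 1.3-fold lower number from compound 3 to compound 4 (0.13 log units; within the scatter) gives the first look at the chain on the imidazole ring: going from ethyl to butyl leaves the number unchanged within the scatter, so this spot accepts the two extra carbons without a measurable loss. The advantage of the 1-methyl-1H-imidazol-4-yl ring over both pyrazole rings also holds with the longer chain, as the step of a 6.0-fold lower number from compound 2 to compound 4 (0.78 log units; beyond the scatter) and the step of a 4.3-fold lower number from compound 1 to compound 4 (0.63 log units; beyond the scatter) both lie beyond the scatter. No supporting measurement is available to explain why the longer chain makes no measurable difference.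

Going by these compounds, it remains open how far this tolerance extends, for example to a hexyl chain or to a butyl chain ending in an amine or a carboxylic acid. On these data alone, it is also open whether butyl on either pyrazole ring would behave the same way.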